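Swapping the Benzyl Ring Substituent in an Adrenergic Antagonist Series

A few compounds are considered here, and "the series" means these few. Any claim that something is new, unique, unknown or untested is made for them only; others in the source may bear on it.

Measured so far:
compound 1, `COc1cccc(OC)c1OCCNCCOc1ccccc1OCc1cccc(Cl)c1`, gives 7.93
compound 2, `COc1cccc(OC)c1OCCNCCOc1ccccc1OCc1ccc(C)cc1`, gives 8.43

Both numbers come from a functional assay on spleen for antagonist activity at Alpha-1B adrenergic receptor (Rattus norvegicus); on this read-out lower numbers stand for lower potency and higher numbers for higher potency (the scale is a negative logarithm). Compound 2 holds the higher of the two. Within the data shown here, the single measured step, a number 0.50 log units higher from compound 1 to compound 2 (beyond the scatter), is the only guide available. Compound 3, `COc1cccc(OC)c1OCCNCCOc1ccccc1OCc1ccccc1[N+](=O)[O-]`, is not yet measured; it differs from compound 2 by 2-nitrophenyl in place of 4-methylphenyl on a saturated chain carbon bound to an oxygen on an aromatic ring. The measured step changed the same place by a modest amount, so a step of similar size, more likely downward, is expected. Compound 3 is therefore estimated at 8, ranging from 7.3 to 8.7, which is expected to mean a number 0.43 log units lower from compound 2 to compound 3 (beyond the scatter).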

Compound 3, negative logarithm of the antagonist equilibrium constant: 8.56
For compound 3 the middle estimate is 0.56 log units below the measured one; the range from low to high includes it.
By their numbers in this assay, from the lowest: compound 1; then compounds 2 and 3 (each within the scatter of the next).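

In this assay, the larger 2-nitrophenyl in place of 4-methylphenyl gives a number 0.13 log units higher from compound 2 to compound 3 (within the scatter), so these two quite different rings cannot be told apart at this place. Against 3-chlorophenyl, the same group gives a number 0.63 log units higher from compound 1 to compound 3 (beyond the scatter), which leaves compound 1 apart from both. Nothing available explains these differences. Each of the three rings carries a different group at a different ring position, so the group and its position cannot be separated. As far as these compounds go, whether an unsubstituted phenyl, or a 4-chlorophenyl or 2-methylphenyl ring, would fit with these three remains open.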